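This account rests on a few compounds, and the source may have more. Where it says the series, first, only, none or still open, it means among the compounds named here.

Three compounds share one core. In a functional assay for agonist activity at Alpha-1D adrenergic receptor (Homo sapiens) (on this read-out lower numbers stand for smaller maximal responses and higher numbers for larger maximal responses), compound 1 `CSc1ccc(C)cc1NCC1=NCCN1` gives 107%. Compound 2 `CSc1ccc(F)cc1NCC1=NCCN1` gives 107% in this assay, and compound 3 `CSc1cc(F)ccc1NCC1=NCCN1` gives 75%. Within the data shown here, the only pair that differs in one place is compound 1 and compound 2, fluoro in place of methyl on an aromatic carbon, and that step, no change at the digits printed from compound 1 to compound 2 (within the scatter), stays within the scatter. Compound 2 therefore stands level with compound 1 at the digits shown, the two together giving the highest of the three numbers, while compound 3 lies furthest from it, beyond the scatter.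

Compound 4 `CSc1ccc(Cl)cc1NCC1=NCCN1` is not yet measured. It differs from compound 2 as follows: chloro in place of fluoro on an aromatic carbon. Among the measured compounds shown here, the one step that bears on this swap is the earlier exchange at the carbon para to the methylsulfanyl group, from compound 1 to compound 2, which left the maximal response unchanged. On that basis a step of a number 2 percentage points lower from compound 2 to compound 4 (within the scatter) is expected, none beyond the scatter. Compound 4 is estimated at 105%, with a range from 88% to 120%.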

Compound 4, largest response reached (reported as maximum), in percent of the reference or control that the assay uses: 106%
Estimate against measurement, compound 4: 1 percentage points below; the range from low to high includes it.
By their numbers in this assay, from the lowest: compound 3; then compounds 4, 1 and 2 (each within the scatter of the next).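

In this assay the carbon para to a methylsulfanyl group now carries a third group: chloro in place of fluoro gives a number 1 percentage points lower from compound 2 to compound 4 (within the scatter) and chloro in place of methyl gives a number 1 percentage points lower from compound 1 to compound 4 (within the scatter) at this carbon. Where the earlier compounds offered a single exchange at this carbon, three groups now give maximal responses that cannot be told apart, so the response here is unchanged across methyl, fluoro and chloro. No measurement at hand explains this sameness.

Going by these compounds, whether the response stays at this level with a methoxy group, an amine or a carboxylic acid on this carbon remains open. Also open, on these data alone, is whether chloro would behave the same way at the carbon that bears fluoro in compound 3.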